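This account rests on a few compounds, and the source may have more. Where it says the series, first, only, none or still open, it means among the compounds named here.

Three compounds sharing one core have been measured in a functional assay on HeLa cells (Homo sapiens) for cytotoxicity, read by WST assay, with a stated time of 48 h; on this read-out higher numbers stand for weaker inhibition and lower numbers for stronger inhibition:

compound 1 `Oc1ccccc1/C=C/C[C@H]1C[C@@H]([C@@H](O)c2ccccc2)CO[C@@H]1c1ccccc1` gives 21800 nM
compound 2 `COc1cccc(/C=C/C[C@H]2C[C@@H]([C@@H](O)c3ccccc3)CO[C@@H]2c2ccccc2)c1` gives 10900 nM
compound 3 `COc1ccccc1/C=C/C[C@H]1C[C@@H]([C@@H](O)c2ccccc2)CO[C@@H]1c1ccccc1` gives 14700 nM

Compound 3 holds no separate place among these numbers, since a 1.3-fold higher number from compound 2 to compound 3 (0.13 log units; within the scatter) and a 1.5-fold lower number from compound 1 to compound 3 (0.17 log units; within the scatter) both lie within the scatter. Compound 4 `Cc1ccc(/C=C/C[C@H]2C[C@@H]([C@@H](O)c3ccccc3)CO[C@@H]2c2ccccc2)cc1C` has yet to be measured. Compared with compound 3, it carries 3,4-dimethylphenyl in place of 2-methoxyphenyl on a double-bonded chain carbon bound to a double-bonded chain carbon.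

Within the data shown here, three measured steps bear on this change. Exchanging the group at that same place gave a 2.0-fold lower number from compound 1 to compound 2 (0.30 log units; within the scatter) and a 1.3-fold higher number from compound 2 to compound 3 (0.13 log units; within the scatter), while methyl in place of hydrogen on the oxygen gave a 1.5-fold lower number from compound 1 to compound 3 (0.17 log units; within the scatter). All three stay within the scatter. Among the measured compounds shown here, none of the measured compounds carries 3,4-dimethylphenyl, so these steps offer only indirect guidance, and the range has to stay wide. Given the size of a 1.3-fold higher number from compound 2 to compound 3 (0.13 log units; within the scatter), no step beyond the scatter is expected in this assay, and no direction is favoured.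

The estimated step is a 1.1-fold lower number from compound 3 to compound 4 (0.05 log units; within the scatter).

Compound 4 is expected at 13000 nM, with an estimated range from 6500 nM to 26000 nM.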

Compound 4, half-maximal inhibitory concentration: 10000 nM
For compound 4 the middle estimate is 1.3-fold (0.11 log units) above the measured one; low and high end bracket the measured number.
By their numbers in this assay, from the lowest: compounds 4, 2, 3 and 1 (each within the scatter of the next, the first and the last beyond it).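

In this assay, 3,4-dimethylphenyl in place of 2-methoxyphenyl gives a 1.5-fold lower number from compound 3 to compound 4 (0.17 log units; within the scatter) and in place of 3-methoxyphenyl gives a 1.1-fold lower number from compound 2 to compound 4 (0.04 log units; within the scatter), so at this place a ring of carbon only, with no hydrogen-bond acceptor, stays within the scatter of both methoxy compounds. Against 2-hydroxyphenyl the same group gives a 2.2-fold lower number from compound 1 to compound 4 (0.34 log units; beyond the scatter), the first step in this series to pass the scatter, though only modestly, and it separates just the two ends of the series, as compound 2 and compound 3 remain within the scatter of both compound 1 and compound 4. Nothing measured here accounts for this difference.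

The compounds shown leave open whether an amine or a carboxylic acid on this aromatic ring, or a chlorine atom in place of a methyl, would carry the number further from that of compound 1. They also do not tell whether 3-methylphenyl or 4-methylphenyl alone would match 3,4-dimethylphenyl, or whether a longer chain to the ring would change the number at all.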